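Amide nitrogen substituent swap at the assay limit

The source may hold more compounds than are shown below. What is called first, only, known or untested is meant among the compounds shown, and "the series" means these compounds.

The shared core of compound 1 `O=C(Nc1cccc(O)c1)c1cccc(N2C(=O)c3ccccc3C2=O)c1` carries an amide whose nitrogen bears 3-hydroxyphenyl; in an in vitro functional assay on HEK293-A cells for antagonist activity at metabotropic glutamate receptor 5 (Rattus norvegicus), read by calcium flux (a higher number here means a weaker inhibitor, a lower number a stronger inhibitor), compound 1 gives 7790 nM. Compound 2 `O=C(Nc1cccnc1)c1cccc(N2C(=O)c3ccccc3C2=O)c1` carries pyridin-3-yl on that nitrogen, and in this assay compound 2 returns only the assay limit > 30000 nM. Compound 3 `O=C(NC1CC1)c1cccc(N2C(=O)c3ccccc3C2=O)c1` carries cyclopropyl there, and in this assay compound 3 likewise returns only the limit > 30000 nM. Compound 3 thus stands at the far weak end of the numbers shown, together with compound 2 at the same limit (the limit of > 30000 nM in this assay, at which 2 of the 3 values shown sit). The step from the hydroxyphenyl analogue reads an at least 3.8-fold higher number from compound 1 to compound 3 (0.58 log units; beyond the scatter), while a step that the two limits leave unreadable from compound 2 to compound 3. Compound 4 `O=C(NC1CC2CCC1C2)c1cccc(N2C(=O)c3ccccc3C2=O)c1` differs from compound 3 in that (a group of 7 heavy atoms (7 carbon; 2 five-membered non-aromatic rings of carbon only) in place of a group of 3 heavy atoms (3 carbon; one three-membered non-aromatic ring of carbon only), on an amide-type nitrogen). Among the compounds with values here, no measured step exchanges one ring of carbon only for another on this nitrogen; the single step ending at compound 3, an at least 3.8-fold higher number from compound 1 to compound 3 (0.58 log units; beyond the scatter), concerns loss of the 3-hydroxyphenyl group and gives no direction for the present change. The expectation in this assay is therefore an at least 1.2-fold lower number from compound 3 to compound 4 (0.07 log units; that floor lies within the scatter), with a real chance that compound 4 again sits at the limit. Compound 4 is estimated at 25000 nM, within 5000 nM to 100000 nM.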

Compound 4, half-maximal inhibitory concentration: > 30000 nM
Compound 4 gave a limit, no number; the forecaster's own chance of this, stated with the estimate: 55%; middle value at least 1.2-fold (0.07 log units) away from the limit.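

In this assay compound 4 gives > 30000 nM as a limit of the assay, not a number. Enlarging the carbon-only ring group from cyclopropyl to the group of 7 heavy atoms therefore recovers no measurable value on this amide-type nitrogen, although the steps among compounds 2, 3 and 4 cannot be read. an at least 3.8-fold higher number from compound 1 to compound 4 (0.58 log units; beyond the scatter) is the reading against 3-hydroxyphenyl, so a carbon-only group of the same heavy-atom count as 3-hydroxyphenyl does not match compound 1 in this assay.

Open, on these data alone, is whether the number for compound 1 depends on the hydroxyl or on the aromatic ring of carbon only, a question that an unsubstituted phenyl or a benzyl group on this nitrogen would address. The reading of this position still rests on one number and otherwise on the assay limit: the limit of > 30000 nM in this assay, at which 3 of the 4 values shown sit.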